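A few compounds are considered here, and "the series" means these few. Any claim that something is new, unique, unknown or untested is made for them only; others in the source may bear on it.

Measured in a physicochemical assay for solubility; a higher number here means a more soluble compound, a lower number a less soluble compound:
- Compound 1 `CC(C)(C)C(=O)N1CCC[C@H]1C(=O)N1CCC(NS(=O)(=O)c2cc(S(=O)(=O)c3ccccc3)ccc2C(F)(F)F)CC1`: 50000 nM
- Compound 2 `CC(C)(C)CC(=O)N1CCC[C@H]1C(=O)N1CCC(NS(=O)(=O)c2cc(S(=O)(=O)c3ccccc3)ccc2C(F)(F)F)CC1`: 25000 nM
- Compound 3 `CCNC(=O)N1CCC[C@H]1C(=O)N1CCC(NS(=O)(=O)c2cc(S(=O)(=O)c3ccccc3)ccc2C(F)(F)F)CC1`: 100000 nM

Compound 3, at 100000 nM, is level within the scatter with its closest neighbour, a 2.0-fold higher number from compound 1 to compound 3 (0.30 log units; within the scatter), and clearly apart from the remaining compound, a 4.0-fold higher number from compound 2 to compound 3 (0.60 log units; beyond the scatter).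

Compound 4 `O=C([C@@H]1CCCN1C(=O)Nc1ccccc1)N1CCC(NS(=O)(=O)c2cc(S(=O)(=O)c3ccccc3)ccc2C(F)(F)F)CC1` has not been measured yet. It keeps the shared core and has phenyl in place of ethyl on an amide-type nitrogen.

Going by the values given here, three measured steps bear on this change, all of them swaps of the group on the same carbonyl carbon. Two are small: a 2.0-fold lower number from compound 1 to compound 2 (0.30 log units; within the scatter) and a 2.0-fold higher number from compound 1 to compound 3 (0.30 log units; within the scatter). The third, a 4.0-fold higher number from compound 2 to compound 3 (0.60 log units; beyond the scatter), is modest and the only one beyond the scatter. Among the compounds with values here, no measured compound carries a ring in this group, so the data cannot show directly what a ring does here.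

The closest guide is compound 2, whose all-carbon neopentyl group gives 25000 nM. Compound 1 goes against this reading, since its all-carbon tert-butyl group gives 50000 nM. A modest drop is therefore expected, with the direction held only loosely. The expected step is a 4.0-fold lower number from compound 3 to compound 4 (0.60 log units; beyond the scatter). For compound 4 the estimated value is 25000 nM, with an expected range of 8000 nM to 70000 nM.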

Compound 4, solubility: 25000 nM
The estimate for compound 4 equals the measured number at the digits printed, and the stated range covers the measured number.
By their numbers in this assay, from the lowest: compounds 2, 4, 1 and 3 (each within the scatter of the next, the first and the last beyond it).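

Swapping ethyl for phenyl on the amide-type nitrogen gives the first reading for a ring in this group: in this assay there is a 4.0-fold lower number from compound 3 to compound 4 (0.60 log units; beyond the scatter), a modest step. The nitrogen itself is present in both compounds, so its presence alone does not fix the number, and the group it carries can shift the read-out by a step beyond the scatter. The anilino group also sits level with both all-carbon groups, with no change at the digits printed from compound 2 to compound 4 (within the scatter) and a 2.0-fold lower number from compound 1 to compound 4 (0.30 log units; within the scatter), so a ring here gives a number that cannot be told apart from those of neopentyl and tert-butyl, and no measurement shown explains why phenyl lowers the number relative to ethyl.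

Phenyl differs from ethyl in both its ring and its count of carbons, so these two features remain unseparated, and a butyl chain or a cyclohexyl ring on the same nitrogen could show which of them matters. From the compounds shown here alone, it also remains open whether a phenyl ring carrying a carboxylic acid or an amine would move the number back towards that of compound 3.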